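Urea-for-amide switch on the trifluoromethylphenyl arm

The source may hold more compounds than are shown below. What is called first, only, known or untested is meant among the compounds shown, and "the series" means these compounds.

Two compounds of the series have numbers in a functional assay on UACC-62 cells (Homo sapiens) for inhibition, read by sulforhodamine B assay, with a stated time of 48 h; a higher number here means a weaker inhibitor of growth, a lower number a stronger inhibitor of growth. Compound 1 `COc1cc(-c2nn(-c3cccc(NC(=O)c4cccc(C(F)(F)F)c4)c3)cc2-c2ccncc2)ccc1Cl` gives 1940 nM, the highest of the two; compound 2 `O=C(Nc1cccc(-n2cc(-c3ccncc3)c(-c3ccc(Cl)c(O)c3)n2)c1)Nc1cc(C(F)(F)F)cc(C(F)(F)F)c1` gives 749 nM, and the gap between them lies beyond the scatter. Compound 2 differs from compound 1 in more than one place, so no single-step comparison exists among the measured pair.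

Compound 3 `COc1cc(-c2nn(-c3cccc(NC(=O)Nc4ccc(Cl)c(C(F)(F)F)c4)c3)cc2-c2ccncc2)ccc1Cl` is not yet measured. It differs from compound 1 in one place: (4-chloro-3-(trifluoromethyl)phenyl)amino in place of 3-(trifluoromethyl)phenyl on a carbonyl carbon. Compound 3 thereby moves toward the linkage seen in compound 2, which gives 749 nM, although that compound also differs elsewhere.

For compound 3 a step downward is expected in this assay, of a size a 2.3-fold lower number from compound 1 to compound 3 (0.36 log units; beyond the scatter), beyond the scatter but uncertain, resting only on the value of compound 2 749 nM. The estimate for compound 3 is 850 nM, with a range from 300 nM to 2500 nM.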

Compound 3, concentration for 50% growth inhibition: 737 nM
Beside the measured number, compound 3's estimate is 1.2-fold (0.06 log units) above it; the measured number falls inside the stated range.
By their numbers in this assay, from the lowest: compounds 3 and 2 (each within the scatter of the next); then compound 1.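

For the compounds shown here, on the carbonyl carbon whose other neighbour is the amide-type nitrogen, (4-chloro-3-(trifluoromethyl)phenyl)amino in place of 3-(trifluoromethyl)phenyl gives a 2.6-fold lower number from compound 1 to compound 3 (0.42 log units; beyond the scatter) in this assay, the first single-place step. With the rest of compound 1 held fixed, this position therefore responds to substitution, and the entering group brings both an amino nitrogen and a chlorine that the leaving group lacks. No supporting measurement accounts for this step.

Going by these compounds alone, the single step changes the nitrogen and the chlorine together, so their separate contributions remain unresolved. A (3-(trifluoromethyl)phenyl)amino group without the chlorine would separate them, while a saturated cyclohexylamino group on the same carbonyl carbon would test whether the aromatic ring is needed there.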